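A few compounds are considered here, and "the series" means these few. Any claim that something is new, unique, unknown or untested is made for them only; others in the source may bear on it.

The measured compounds, each in an ADME assay on MT4 cells (Homo sapiens) for cytotoxicity, read by MTT assay, with a stated time of 5 days; a lower number here means that less compound is tolerated, a higher number that more compound is tolerated:

Compound 1, `CCCCNc1cc(Oc2c(OC)cc3cc(C#N)ccc3c2OC)nc(Nc2ccc(C#N)cc2)n1`, gives > 125000 nM, which is a limit of the assay rather than a number.
Compound 2, `CCCCCNc1cc(Oc2c(OC)cc3cc(C#N)ccc3c2OC)nc(Nc2ccc(C#N)cc2)n1`, gives > 125000 nM, also a limit.
Compound 3, `COc1cc2cc(C#N)ccc2c(OC)c1Oc1cc(NC2CC2)nc(Nc2ccc(C#N)cc2)n1`, gives > 125000 nM, again a limit.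

Compound 3 therefore stands at the limit of this assay, and the two other values shown are limits as well, so none of the three can be placed above or below another. The steps a step that the two limits leave unreadable from compound 1 to compound 2, a step that the two limits leave unreadable from compound 1 to compound 3 and a step that the two limits leave unreadable from compound 2 to compound 3 cannot be read, because of the limit of > 125000 nM in this assay, at which 3 of the 3 values shown sit. Compound 4, `COc1cc2cc(C#N)ccc2c(OC)c1Oc1cc(NCCCO)nc(Nc2ccc(C#N)cc2)n1`, differs from compound 3 by 3-hydroxypropyl in place of cyclopropyl on a nitrogen on an aromatic ring. The two steps that also changed the group on this nitrogen, from compound 1 and compound 2 to compound 3, gave no readable size, so nothing measured points to a change in this assay here. The step of a number no higher from compound 3 to compound 4 (the limit leaves the size open) is expected to show no effect beyond the scatter. Compound 4 is estimated at 125000 nM, within 50000 nM to 125000 nM, most likely reported again as a limit.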

Compound 4, half-maximal cytotoxic concentration: 23500 nM
Compound 4: middle estimate off by 5.3-fold (0.73 log units), on the high side, outside the stated range (below it).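

In this assay, within the data shown here, this nitrogen is the first place where a change of group gives a readable result: 3-hydroxypropyl in place of cyclopropyl gives an at least 5.3-fold lower number from compound 3 to compound 4 (0.72 log units; beyond the scatter), so less compound is tolerated. The comparisons with the two plain chains point the same way, with an at least 5.3-fold lower number from compound 2 to compound 4 (0.72 log units; beyond the scatter) and an at least 5.3-fold lower number from compound 1 to compound 4 (0.72 log units; beyond the scatter), which shows that the group on this nitrogen can matter for tolerance and that a chain carrying hydroxy differs here from butyl and pentyl. The true size of these steps remains unknown because each starts from a compound at a limit: the limit of > 125000 nM in this assay, at which 3 of the 4 values shown sit.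

The steps among compound 1, compound 2 and compound 3 cannot be read. Going by these compounds, it also remains open whether a methoxy group or an amine at the end of the same chain would lower the number as hydroxy does.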